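From propyl to butoxymethyl on a shared core

The compounds below may be only part of what the source reports. "The series", "measured", "known", "first", "only" and "open" are said of these compounds alone.

In an ADME assay on HeLa cells (Homo sapiens) for cytotoxicity, read by LDH release, with a stated time of 24 h (a higher number here means a weaker inhibitor, a lower number a stronger inhibitor), three compounds have been measured:
- compound 1 `COCCOCCOCCOCc1ccc2c(Br)cc(Br)c(O)c2n1` gives 100000 nM
- compound 2 `COCCOCc1ccc2c(Br)cc(Br)c(O)c2n1` gives > 100000 nM, which is a limit
- compound 3 `CCCc1ccc2c(Br)cc(Br)c(O)c2n1` gives > 50000 nM, which is a limit

Compound 3 therefore stands at a limit and has no number of its own. Compound 4 `CCCCOCc1ccc2c(Br)cc(Br)c(O)c2n1` differs from it by butoxy in place of ethyl on a saturated chain carbon bound to an aromatic carbon. At that same place there is a step that the two limits leave unreadable from compound 2 to compound 3. Further out on the chain there is a number no lower from compound 1 to compound 2 (the limit leaves the size open). Both steps bear on the change, but neither has a size that can be read. For the measured compounds named here, compound 1 is the only one with a plain number (100000 nM). No step beyond the scatter is expected in this assay, and the estimated step is a step that the limit leaves unreadable from compound 3 to compound 4, with no firm direction. For compound 4 the expected value is 80000 nM (estimated range 30000 nM to 150000 nM).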

Compound 4, half-maximal inhibitory concentration: > 50000 nM
Compound 4: no number, only a limit; the forecaster's own chance of this, stated with the estimate: 70%; the middle value lies beyond the limit too.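

In this assay compound 4 gives > 50000 nM, which is a limit, so its steps from compound 1, compound 2 and compound 3 cannot be read. The compounds shown leave open whether propyl and butoxymethyl on the shared core differ in this read-out at all.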